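A Ring Swap on the Side-Chain Amine Nitrogen

The source may hold more compounds than are shown below. What is called first, only, known or untested is meant among the compounds shown, and "the series" means these compounds.

Compound 1 `CCO/C(O)=C1\C(C)=NC(COCCNc2n[nH]c(N)n2)=C(C(=O)OC)C1c1cccc(Cl)c1Cl`: 100 nM
Compound 2 `CCO/C(O)=C1\C(COCCNc2nc(N)n(C)n2)=NC(C)=C(C(=O)OC)C1c1cccc(Cl)c1Cl`: 3.98 nM

In a functional assay (aorta) with Rattus norvegicus as the target (a higher number here means a weaker inhibitor, a lower number a stronger inhibitor), compound 2 gives 3.98 nM, the lower of the two numbers, and compound 1 gives 100 nM, a gap beyond the scatter. Compound 3 `CCO/C(O)=C1\C(COCCNc2n[s+]([O-])nc2OC)=NC(C)=C(C(=O)OC)C1c1cccc(Cl)c1Cl` differs from compound 2 by a group of 8 heavy atoms (3 carbon, 2 nitrogen, 2 oxygen, 1 sulfur; one five-membered aromatic ring with 3 hetero atoms) in place of a group of 7 heavy atoms (3 carbon, 4 nitrogen; one five-membered aromatic ring with 3 hetero atoms), on an amine nitrogen. Going by the values given here, no measured pair shows the effect of this particular change, so its direction is uncertain. A modest weakening is expected, estimated as a 2.5-fold higher number from compound 2 to compound 3 (0.40 log units; beyond the scatter). Compound 3 is therefore expected to give about 10 nM in this assay, with a likely range from 2 nM to 60 nM.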

Compound 3, half-maximal inhibitory concentration: 10 nM
Beside the measured number, compound 3's estimate shows no gap at the digits printed; low and high end bracket the measured number.
By their numbers in this assay, from the lowest: compound 2; then compound 3; then compound 1.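

In this assay, replacing the 5-amino-1-methyl-1H-1,2,4-triazol-3-yl group on the amine nitrogen with a ring containing sulfur and oxygen gives a 2.5-fold higher number from compound 2 to compound 3 (0.40 log units; beyond the scatter). This amine nitrogen can therefore carry a different five-membered aromatic ring, one with 0 hydrogen-bond donors instead of 1, at the price of only a modest weakening. Nothing available explains the size of this step. A single pair cannot separate the loss of the donor from the other differences between the rings. Going by these compounds, how a phenyl ring or a methyl group on this nitrogen would compare remains open.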